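Removing the bromo from compound 2: what to expect

The source may hold more compounds than are shown below. What is called first, only, known or untested is meant among the compounds shown, and "the series" means these compounds.

Measured so far in a functional assay on A549 cells (Homo sapiens) for antiproliferative activity, read by MTT assay, with a stated time of 48 h; a lower number here means a stronger inhibitor, a higher number a weaker inhibitor:
compound 1 `O=c1cc(-n2cc(COc3ccccc3O)nn2)c2cc(Br)ccc2o1` gives 7940 nM
compound 2 `O=c1cc(-n2cc(COc3ccc(F)cc3)nn2)c2cc(Br)ccc2o1` gives 850 nM

For the measured compounds named here, compound 2 stands lowest of the two numbers so far. Going by the values given here, its only neighbour is compound 1, and the step between them, a 9.3-fold lower number from compound 1 to compound 2 (0.97 log units; beyond the scatter), came from exchanging the aryl group on the oxygen on the saturated carbon; the fused core was left untouched in that step.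

Compound 3 `O=c1cc(-n2cc(COc3ccc(F)cc3)nn2)c2ccccc2o1` differs from compound 2 in one place: hydrogen in place of bromo on an aromatic carbon. Among the compounds with values here, no measured step touches this part of the core. Within the data shown here, the single step available, a 9.3-fold lower number from compound 1 to compound 2 (0.97 log units; beyond the scatter), concerns a different part of the molecule and so offers no guide to the size or direction of the present change. With only the two numbers to rest on, a step of modest size at most is expected in this assay, leaning toward a higher number rather than a lower one, roughly a 1.8-fold higher number from compound 2 to compound 3 (0.25 log units; within the scatter). Compound 3 is accordingly estimated at 1500 nM, with a range from 500 nM to 5000 nM.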

Compound 3, half-maximal inhibitory concentration: 680 nM
The estimate for compound 3 lay 2.2-fold (0.34 log units) above the measured number; the measured number falls inside the stated range.
By their numbers in this assay, from the lowest: compounds 3 and 2 (each within the scatter of the next); then compound 1.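

In this assay, hydrogen in place of bromo on this aromatic carbon gives a 1.3-fold lower number from compound 2 to compound 3 (0.10 log units; within the scatter), so with the 4-fluorophenyl group held fixed, the two compounds cannot be told apart at this position. Both earlier compounds carried the bromo and so could not show this: the first direct test of that group finds that a value in the range of compound 2 does not depend on a bromine atom at this carbon. For the compounds shown here, nothing available explains this outcome, and the result says only that this one exchange, in this one setting, has no effect beyond the scatter.

From the compounds shown here alone, it remains open whether bromo and hydrogen would also stand level with the 2-hydroxyphenyl group of compound 1 in place of the 4-fluorophenyl group, since a single pair cannot show whether the result carries over to another aryl group. Also open, going by these compounds, is how a larger or different group on this same aromatic carbon, such as a methoxy group, an amine or a carboxylic acid, would read in this assay.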